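Changing the Pendant Ring on a Shared Core

The source may report more compounds than this note shows. Statements on the series, on what has been measured and on what is new or still open speak of the compounds shown alone.

Compound 1 `COc1ccc(C2=NO[C@]3(C2)C(=O)O[C@@H]2[C@H]3CC[C@H](C)[C@]3(O)C=CC(=O)[C@@]23C)cc1`: 1.47
Compound 2 `C[C@H]1CC[C@@H]2[C@@H](OC(=O)[C@]23CC(c2ccccc2[N+](=O)[O-])=NO3)[C@]2(C)C(=O)C=C[C@@]12O`: 1.37

Both compounds were measured in a physicochemical assay for lipophilicity; on this read-out lower numbers stand for lower lipophilicity and higher numbers for higher lipophilicity. Compound 1 carries the larger of the two numbers, with compound 2 nearest, but the step of a number 0.10 log units lower from compound 1 to compound 2 (within the scatter) is within the scatter, so the two values are treated as alike. Compound 3 `Cc1ccccc1C1=NO[C@]2(C1)C(=O)O[C@@H]1[C@H]2CC[C@H](C)[C@]2(O)C=CC(=O)[C@@]12C` has not been measured. It differs from compound 1 in one place: 2-methylphenyl in place of 4-methoxyphenyl on a carbon with a double bond to nitrogen. Among the compounds with values here, the only measured step, from compound 1 to compound 2, exchanged the same 4-methoxyphenyl for a 2-nitrophenyl and stayed within the scatter; no measured pair contains a 2-methylphenyl, so direct guidance is thin. For compound 3 a modest rise in this assay is expected, a number 0.38 log units higher from compound 1 to compound 3 (beyond the scatter). Compound 3 is therefore estimated at 1.85, with a range from 1.45 to 2.25.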

Compound 3, partition coefficient: 1.86
Compound 3: middle estimate off by 0.01 log units, on the low side, within the range that was stated.
By their numbers in this assay, from the lowest: compounds 2 and 1 (each within the scatter of the next); then compound 3.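

In this assay, the position on the carbon with a double bond to nitrogen now proves able to shift the number beyond the scatter: 2-methylphenyl in place of 4-methoxyphenyl gives a number 0.39 log units higher from compound 1 to compound 3 (beyond the scatter). Methyl in place of nitro on an aromatic carbon gives a number 0.49 log units higher from compound 2 to compound 3 (beyond the scatter), so compound 3 stands apart from the other two compounds, whose values lie within the scatter of each other. Nothing measured here accounts for this difference.

On these data alone, all three compounds carry a six-membered aromatic ring of carbon at this position, so the effect of an amine, a carboxylic acid or a longer chain there remains open. As far as these compounds go, it is also open whether 4-methylphenyl would give a number like that of 2-methylphenyl.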